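The compounds below may be only part of what the source reports. "The series", "measured", "known", "first", "only" and "open" are said of these compounds alone.

In a functional assay on MCF7 cells (Homo sapiens) for cytotoxicity, read by MTT assay, with a stated time of 24 h (a higher number here means a weaker inhibitor, a lower number a stronger inhibitor), compound 1 (`Cc1ncc([N+](=O)[O-])n1CCOc1ccccc1`) gives 106 ug/mL. Within the data shown here, the only other measured compound, compound 2 (`Cc1ncc([N+](=O)[O-])n1CCOc1cccc([N+](=O)[O-])c1`), gives 71.7 ug/mL, and these two numbers cannot be told apart within the usual scatter of repeated measurements. Compound 3 (`Cc1ncc([N+](=O)[O-])n1CCOc1ccccc1[N+](=O)[O-]`) has not yet been measured. It is compound 1 with a single change, nitro in place of hydrogen on an aromatic carbon, ortho to a large group.

Among the measured compounds shown here, only one measured step bears on this change. The same exchange, made at another carbon of that ring, gave a 1.5-fold lower number from compound 1 to compound 2 (0.17 log units; within the scatter). For the measured compounds named here, a single example is thin evidence, and no measurement yet shows what the new place on the ring does to the number. Going by the values given here, with compound 2 at 71.7 ug/mL as the only guide, no step beyond the scatter is expected in this assay. The expected result is a 1.2-fold lower number from compound 1 to compound 3 (0.10 log units; within the scatter), an estimate that leans the same way as the measured step but stays within the scatter. For compound 3 the estimated value is 85 ug/mL, with an expected range from 45 ug/mL to 150 ug/mL.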

Compound 3, half-maximal inhibitory concentration: 583 ug/mL
Estimate against measurement, compound 3: 6.9-fold (0.84 log units) below; measured number above the stated range.
By their numbers in this assay, from the lowest: compounds 2 and 1 (each within the scatter of the next); then compound 3.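

In this assay, among these compounds, nitro in place of hydrogen on an aromatic carbon, ortho to a large group, gives a 5.5-fold higher number from compound 1 to compound 3 (0.74 log units; beyond the scatter) and so marks a weaker inhibitor, the first step in this small set that clearly exceeds ordinary measurement noise. The same exchange at another carbon of that ring gave a 1.5-fold lower number from compound 1 to compound 2 (0.17 log units; within the scatter) and could not be told apart from noise, so across these three compounds the result of adding a nitro group depends on where on the ring it is placed. Nothing measured here explains why the number rises at this place.

The compounds shown leave open whether another group at this same place, such as an amine, a methoxy group or a carboxylic acid, would raise the number as well, or whether this step belongs to nitro alone. They also leave open how nitro behaves at the other carbons of the ring, and whether a longer chain linking the shared core to the ring would alter the size of this step.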